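A few compounds are considered here, and "the series" means these few. Any claim that something is new, unique, unknown or untested is made for them only; others in the source may bear on it.

Going by the values given here, compound 2 `CCC(C)(C)/N=C(\NC#N)Nc1cc(Cl)cc(Cl)c1` gives 24000 nM in a functional assay on Beta-TC3 cells (Rattus norvegicus) with Beta-TC3 (Mus musculus) as the target, using a membrane potential dye (a higher number here means a weaker inhibitor, a lower number a stronger inhibitor), the highest of the two numbers so far; the nearest is compound 1 `CC(C)CC/N=C(\NC#N)Nc1cc(Cl)cc(Cl)c1`, which in this assay gives 800 nM. Compound 3 `N#CN/C(=N\C1CCCC1)Nc1cc(Cl)cc(Cl)c1` differs from compound 2 by cyclopentyl in place of 1,1-dimethylpropyl on a double-bonded nitrogen. Among the compounds with values here, the only measured step touching this position is a 30-fold higher number from compound 1 to compound 2 (1.48 log units; beyond the scatter), so changes here can move the read-out a long way. Compound 3 carries a five-membered ring where compound 2 has an open chain, and for compound 3 the expected step is an 8.0-fold lower number from compound 2 to compound 3 (0.90 log units; beyond the scatter), smaller than the measured one and in the opposite direction. Compound 3 is therefore estimated at 3000 nM, within 700 nM to 13000 nM.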

Compound 3, half-maximal inhibitory concentration: 12000 nM
Compound 3: the middle estimate sits 4.0-fold (0.60 log units) below what was measured; low and high end bracket the measured number.
By their numbers in this assay, from the lowest: compound 1; then compounds 3 and 2 (each within the scatter of the next).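

In this assay, cyclopentyl in place of 1,1-dimethylpropyl gives a 2.0-fold lower number from compound 2 to compound 3 (0.30 log units; within the scatter) and so does not separate the ring from the open chain at this position. Against isopentyl, the same ring gives a 15-fold higher number from compound 1 to compound 3 (1.18 log units; beyond the scatter) and thus joins 1,1-dimethylpropyl on the far side of the large gap, leaving isopentyl as the only one of the three groups with the low number. Nothing at hand accounts for this gap. The compounds shown leave open where a straight pentyl chain or a cyclohexyl group would fall, and therefore whether the low number belongs to isopentyl alone.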